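Replacing Chloro with Methoxy in Compound 3

The source may report more compounds than this note shows. Statements on the series, on what has been measured and on what is new or still open speak of the compounds shown alone.

Of the compounds shown here, three sharing one core have been measured in a functional assay on P388D1 cells (Homo sapiens) for antiproliferative activity, read by sulforhodamine B assay, with a stated time of 48 h; on this read-out lower numbers stand for stronger inhibition and higher numbers for weaker inhibition. Compound 1 `CCc1cccc(NS(=O)(=O)c2ccc(N3CCNC3=O)cc2)c1` gives 250 nM, compound 2 `Cc1cc(C)cc(NS(=O)(=O)c2ccc(N3CCNC3=O)cc2)c1` gives 210 nM, and compound 3 `O=C1NCCN1c1ccc(S(=O)(=O)Nc2cccc(Cl)c2)cc1` gives 78 nM. Compound 3 therefore has the lowest number of the three, and it is the strongest inhibitor among them.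

Compound 4 `COc1cccc(NS(=O)(=O)c2ccc(N3CCNC3=O)cc2)c1` has not yet been measured. It carries methoxy in place of chloro on an aromatic carbon. The same difference can be read as 3-chlorophenyl to 3-methoxyphenyl.

For the measured compounds named here, no measured compound carries a methoxy group, so the closest guides are the steps that arrive at the chloro compound. These are a 3.2-fold lower number from compound 1 to compound 3 (0.51 log units; beyond the scatter) and a 2.7-fold lower number from compound 2 to compound 3 (0.43 log units; beyond the scatter), both modest. Compounds 1 and 2 differ little from each other, with a 1.2-fold lower number from compound 1 to compound 2 (0.08 log units; within the scatter). Both replacements of chloro seen so far therefore give a higher number, though only two such replacements are available.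

A similar modest rise is expected for methoxy, although a step within the scatter remains possible. The expected step in this assay is a 2.2-fold higher number from compound 3 to compound 4 (0.34 log units; beyond the scatter). The estimate for compound 4 is 170 nM, with an expected range from 60 nM to 450 nM.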

Compound 4, half-maximal inhibitory concentration: 250 nM
The estimate for compound 4 lay 1.5-fold (0.17 log units) below the measured number; the range from low to high includes it.
By their numbers in this assay, from the lowest: compound 3; then compounds 2, 1 and 4 (each within the scatter of the next).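

In this assay, the change from chloro to methoxy gives a 3.2-fold higher number from compound 3 to compound 4 (0.51 log units; beyond the scatter) and so adds a third group, and the first one carrying an oxygen, that reads higher than chloro at this position, with no compound shown going against that. The other two comparisons are flat, with a 1.2-fold higher number from compound 2 to compound 4 (0.08 log units; within the scatter) and no change at the digits printed from compound 1 to compound 4 (within the scatter) on the same scale, so the 3-methoxyphenyl, 3-ethylphenyl and 3,5-dimethylphenyl compounds cannot be told apart on this read-out, and the hydrogen-bond acceptor that enters with methoxy brings no visible separation from the other two groups. That leaves compound 3 as the strongest inhibitor of the four, but nothing available explains why chloro stands apart.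

The compounds shown leave open whether the low number belongs to chloro alone or is shared by other halogens such as fluoro or bromo. They also leave open how quite different groups, such as an amine, a carboxylic acid or a longer chain, would read at this place on the ring.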